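A few compounds are considered here, and "the series" means these few. Any claim that something is new, unique, unknown or untested is made for them only; others in the source may bear on it.

Compound 1 `Cc1ccnc(/C(N)=N/NC(=S)N2CCN(c3ccccn3)CC2)c1` gives 79.4% in a functional assay on A-375 cells (Homo sapiens) for cytotoxicity, read by MTT assay, with a stated time of 72 h, tested at 30 uM; a lower number here means less inhibition of growth, a higher number more inhibition of growth at the concentration tested.
Compound 2 `Cc1ccnc(/C(N)=N/NC(=S)N2CCSCC2)c1` gives 84.9% in this assay.
Compound 3 `N/C(=N\NC(=S)N1CCSCC1)c1ccccn1` gives 86% in this assay.

The three measured numbers lie close together. Compound 2 stands in the middle of them: its nearest neighbour is compound 3, separated by a number 1.1 percentage points higher from compound 2 to compound 3 (within the scatter), which is within the scatter, and compound 1, the furthest, gives 79.4%, a number that the scatter also covers. Going by the values given here, the only change measured in one place, from compound 2 to compound 3, is hydrogen in place of methyl on an aromatic carbon, and it left the number essentially unchanged.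

Compound 4 `Cc1ccnc(/C(N)=N/NC(=S)N2CCCCC2)c1` differs from compound 2 by piperidin-1-yl in place of thiomorpholin-4-yl on a thiocarbonyl carbon. Among the compounds with values here, no measured step touches this part of the molecule, so nothing directly bears on it; what the three compounds show is that changes at either end of the shared core have so far moved this assay by amounts inside the scatter. On that basis no step beyond the scatter is expected from compound 2 to compound 4, with a number 2.9 percentage points lower from compound 2 to compound 4 (within the scatter) as the expected change. Compound 4 is therefore estimated at 82%, within a range from 68% to 93%.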

Compound 4, percent growth inhibition at one concentration: 80%
Estimate against measurement, compound 4: 2 percentage points above; the range from low to high includes it.
By their numbers in this assay, from the lowest: compounds 1, 4, 2 and 3 (each within the scatter of the next).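

Going by these compounds alone, this is the first measured change at the thiocarbonyl carbon that swaps one plain ring for another: piperidin-1-yl has a ring carbon where thiomorpholin-4-yl has its ring sulfur, while the ring size and the count of heavy atoms stay the same. In this assay the step reads a number 4.9 percentage points lower from compound 2 to compound 4 (within the scatter), so at this position the two rings cannot be told apart, and the ring sulfur is not required for growth inhibition of this size in this pair. No other measurement is available here that could explain this result.

The compounds shown leave open whether a ring is needed on the thiocarbonyl carbon at all, which an open-chain group such as dimethylamino could test, and how morpholin-4-yl, with an oxygen atom in the ring position held by sulfur in compound 2, would read in this assay. They also leave open whether hydrogen in place of methyl on an aromatic carbon would leave the number as little changed when piperidin-1-yl sits on the thiocarbonyl carbon.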